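The source may hold more compounds than are shown below. What is called first, only, known or untested is meant among the compounds shown, and "the series" means these compounds.

Compound 1 `COc1cccc(/C=C/C(=O)c2ccc(OC)c3c2OC(C)(C)C=C3)c1`: > 10000 nM
Compound 2 `COc1ccc(C(=O)/C=C/c2cc(OC)c(OC)c(OC)c2)c2c1C=CC(C)(C)O2`: 7650 nM
Compound 3 `CCN(CC)c1ccc(/C=C/C(=O)c2ccc(OC)c3c2OC(C)(C)C=C3)cc1`: 620 nM

Three compounds built on one shared core were examined in a functional assay on HCT-116 cells (Homo sapiens) for antiproliferative activity, read by MTT assay, with a stated time of 24 h; a lower number here means a stronger inhibitor, a higher number a weaker inhibitor. Compound 1 stands at the limit of > 10000 nM in this assay, at which 1 of the 3 values shown sits. In this assay compound 1 gives > 10000 nM, which is a limit of the measurement and not a number. Compound 2 gives 7650 nM in this assay, and compound 3 gives 620 nM. No single-point change connects these three compounds. Only their values can be compared: compound 3 shows the lowest number of the three, compound 2 a higher one, and compound 1 alone falls at the limit.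

Compound 4 `COc1ccc(/C=C/C(=O)c2ccc(OC)c3c2OC(C)(C)C=C3)cn1` has not yet been measured. It differs from compound 1 in one place: 6-methoxypyridin-3-yl in place of 3-methoxyphenyl on a double-bonded chain carbon bound to a double-bonded chain carbon. For the measured compounds named here, the aryl ring bound to the double-bonded chain carbon keeps its methoxy group, and the only change is the ring itself. Going by the values given here, nothing among the measured compounds tests this kind of ring swap, so no step size is known for it. The expectation is that the change from compound 1 to compound 4 produces no step beyond the usual scatter of this assay, in either direction. Compound 4 is therefore estimated at 10000 nM in this assay, with a range from 3000 nM to 30000 nM. This estimate corresponds to a step of a number no higher from compound 1 to compound 4 (the limit leaves the size open), which is expected to be small.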

Compound 4, half-maximal inhibitory concentration: > 10000 nM
Compound 4: no number, only a limit; the forecaster's own chance of this, stated with the estimate: 55%; the middle value sits exactly at the limit.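

Compound 4, like compound 1, gives a limit and not a number in this assay, so the step between compound 1 and compound 4 cannot be read: the limit of > 10000 nM in this assay, at which 2 of the 4 values shown sit. The compounds shown leave open how far 6-methoxypyridin-3-yl and 3-methoxyphenyl on this chain actually differ in this assay, as neither compound carries a readable value.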